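The source may report more compounds than this note shows. Statements on the series, on what has been measured and on what is new or still open speak of the compounds shown alone.

Notes on the series. Compound 1 `CCOC(c1ccccc1)c1ccc(C(C)C)cc(=O)c1O` gives in a functional assay on KB cells (Homo sapiens) for inhibition (a lower number here means a stronger inhibitor, a higher number a weaker inhibitor), a value of 0.3 ug/mL. Compound 2 `CCOC(c1ccc(OC)cc1)c1ccc(C(C)C)cc(=O)c1O` gives in this assay a value of 0.5 ug/mL; the step is a 1.7-fold higher number from compound 1 to compound 2 (0.22 log units; within the scatter). Compound 3 `CC(C)c1ccc(C(c2ccccc2)c2ccc(C(C)C)cc(=O)c2O)c(O)c(=O)c1` gives in this assay a value of 0.3 ug/mL, level with compound 1 at the digits shown and, together with it, the lowest of the three numbers; the gap to compound 2 lies within the scatter. Compound 4 `COc1ccc(C(c2ccc(C(C)C)cc(=O)c2O)c2ccc(C(C)C)cc(=O)c2O)cc1` differs from compound 3 by methoxy in place of hydrogen on an aromatic carbon. Within the data shown here, the only measured step bearing on this change is a 1.7-fold higher number from compound 1 to compound 2 (0.22 log units; within the scatter), which stayed within the scatter, so no step beyond the scatter is expected in this assay. The expected step is no change at the digits printed from compound 3 to compound 4 (within the scatter). For compound 4 the estimate in this assay is 0.3 ug/mL, with a range from 0.15 ug/mL to 0.7 ug/mL.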

Compound 4, concentration for 50% inhibition: 0.5 ug/mL
For compound 4 the middle estimate is 1.7-fold (0.22 log units) below the measured one; measured number inside the range.
By their numbers in this assay, from the lowest: compounds 1, 3, 2 and 4 (each within the scatter of the next).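

The phenyl to 4-methoxyphenyl change can now be read on a second core in this assay, giving a 1.7-fold higher number from compound 3 to compound 4 (0.22 log units; within the scatter). The methoxy therefore leaves the number within the scatter on both cores, and the two steps agree: the same change on two cores in this assay, a 1.7-fold higher number (0.22 log units; within the scatter) from compound 1 to compound 2 and a 1.7-fold higher number (0.22 log units; within the scatter) from compound 3 to compound 4, 1.0-fold (0.00 log units) apart, within the scatter of two such steps

Neither step gives a direction for this position, as both stay within the scatter. Going by these compounds, whether an amine or a carboxylic acid in place of the methoxy, on the same aromatic carbon, would move the number beyond the scatter remains open.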